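This account rests on a few compounds, and the source may have more. Where it says the series, first, only, none or still open, it means among the compounds named here.

Of the compounds shown here, three built on one shared core have been measured in an assay for binding affinity to dual specificity mitogen-activated protein kinase kinase 4 (Homo sapiens), read by KINOMEscan, tested at 100 nM; on this read-out higher numbers stand for a weaker effect at the one concentration tested and lower numbers for a stronger effect. Compound 1 `CCCS(=O)(=O)Nc1ccc(F)c(C(=O)c2n[nH]c3ncc(-c4ccccc4F)cc23)c1F` gives 2%. Compound 2 `CCCS(=O)(=O)Nc1ccc(F)c(C(=O)c2n[nH]c3ncc(-c4cccc(F)c4)cc23)c1F` gives 8.2% in this assay. Compound 3 `CCCS(=O)(=O)Nc1ccc(F)c(C(=O)c2n[nH]c3ncc(-c4ccc(F)cc4)cc23)c1F` gives 2.1% in this assay. Among these three numbers compound 3 is the second highest: its nearest neighbour is compound 1 and its furthest is compound 2, yet both gaps lie within the usual scatter, so the three compounds cannot be told apart on this read-out.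

Compound 4 `CCCS(=O)(=O)Nc1ccc(F)c(C(=O)c2n[nH]c3ncc(-c4cccc(C)c4)cc23)c1F` differs from compound 3 in one place: 3-methylphenyl in place of 4-fluorophenyl on an aromatic carbon. The measured steps that bear on this change all swap one fluorophenyl for another. The step of a number 6.1 percentage points lower from compound 2 to compound 3 (within the scatter) and the step of a number 0.1 percentage points higher from compound 1 to compound 3 (within the scatter) stay within the scatter, and so does a number 6.2 percentage points higher from compound 1 to compound 2 (within the scatter). For the measured compounds named here, no measured step trades a fluorine for a methyl group, so that part of the change has no precedent here. Every change of the fluorophenyl group so far, including a number 6.1 percentage points lower from compound 2 to compound 3 (within the scatter), left the number within the scatter. On that basis the expected step is a number 2.9 percentage points higher from compound 3 to compound 4 (within the scatter), with no direction beyond the scatter. Compound 4 is therefore estimated at 5%, with a range from 1% to 20%.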

Compound 4, a percentage reported as activity, at one concentration (the size of the read-out at that concentration, not a potency): 15%
Compound 4: the middle estimate sits 10 percentage points below what was measured; the measured number falls inside the stated range.
By their numbers in this assay, from the lowest: compounds 1, 3, 2 and 4 (each within the scatter of the next, the first and the last beyond it).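

In this assay, for the compounds shown here, the 3-methylphenyl group gives the first change at this position that stands clear of the usual scatter: a number 12.9 percentage points higher from compound 3 to compound 4 (beyond the scatter), and likewise a number 13 percentage points higher from compound 1 to compound 4 (beyond the scatter), whereas swaps among the fluorophenyl groups alone never did. The separation is only partial, since methyl in place of fluoro gives a number 6.8 percentage points higher from compound 2 to compound 4 (within the scatter), so compound 4 cannot be told apart from compound 2 and the direct trade of a fluorine for a methyl group shows no clear effect on this read-out. Nothing available explains why compound 4 separates from compound 1 and compound 3 but not from compound 2.

The compounds shown leave open whether a methyl group placed elsewhere on this phenyl ring would behave like the one in compound 4, so the role of the group cannot yet be separated from the role of its place. They also leave open how a more different group, such as an amine or a carboxylic acid, would read at this position, and how any of these single-concentration numbers would translate into potency.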